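A few compounds are considered here, and "the series" means these few. Any claim that something is new, unique, unknown or untested is made for them only; others in the source may bear on it.

The series rests on three measured compounds. Among the measured compounds shown here, compound 1 `CC(C)(C)c1ccc(CNC(=O)NCCCCl)cc1` is the one member for which a functional assay on M21 cells (Homo sapiens) for antiproliferative activity, with a stated time of 48 h (on this read-out higher numbers stand for weaker inhibition and lower numbers for stronger inhibition), returns a number: compound 1 gives 11000 nM. Compound 2 `CCCCC(O)c1cccc(NC(=O)NC(=O)CC)c1` reaches only the limit of the assay, and in this assay compound 2 gives > 100000 nM. Compound 3 `CCCCC(OC)c1cccc(NC(=O)NC(=O)CC)c1` likewise stops at the limit, and compound 3 gives > 100000 nM. For the measured compounds named here, the single step among them, a step that the two limits leave unreadable from compound 2 to compound 3, cannot be read, since both of its ends sit at the limit of > 100000 nM in this assay, at which 2 of the 3 values shown sit. Going by the values given here, compound 1 therefore stands alone as the only numerical value shown, the other two values being limits.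

Compound 4 `CC(C)(C)c1ccc(CNC(=O)CCCl)cc1` differs from compound 1 in one place: 2-chloroethyl in place of (3-chloropropyl)amino on a carbonyl carbon. Among the compounds with values here, no measured step touches this change; the only measured step, a step that the two limits leave unreadable from compound 2 to compound 3, concerns an oxygen on a saturated carbon and is in any case unreadable. The expectation for compound 4 thus rests on compound 1 alone, whose value 11000 nM is the only anchor. The estimate for compound 4 is a step of a 2.7-fold higher number from compound 1 to compound 4 (0.44 log units; beyond the scatter) toward weaker inhibition, with wide uncertainty. Compound 4 is expected to give 30000 nM, in a range from 8000 nM to 100000 nM, and a result at the assay limit is possible.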

Compound 4, half-maximal inhibitory concentration: > 100000 nM
Compound 4: no number, only a limit; the forecaster's own chance of this, stated with the estimate: 30%; at least 3.3-fold (0.52 log units) between middle value and limit.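

Among the compounds shown here, replacing (3-chloropropyl)amino with 2-chloroethyl on a carbonyl carbon gives the first step that can be read: an at least 9.0-fold higher number from compound 1 to compound 4 (0.95 log units; beyond the scatter). In this assay compound 4 gives > 100000 nM, which is a limit of the assay and not a number, so the step has a lower bound but no upper one. This position is therefore sensitive to the change, and among the compounds shown a measured value on the shared core of compounds 1 and 4 goes with (3-chloropropyl)amino, leaving compound 1 as the only number against a row of limits: the limit of > 100000 nM in this assay, at which 3 of the 4 values shown sit.

The change alters the amino nitrogen and the chain at once, so the compounds shown cannot say which of the two carries the step; a 3-chloropropyl group on the same carbonyl carbon would keep the longer chain without that nitrogen, while 2-chloroethylamino would keep the nitrogen with the shorter chain. Going by these compounds, whether the chlorine has any part also stays open, as a plain propylamino group on this carbonyl carbon does not appear among them.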